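Methyl in Place of Hydrogen on an Amine Chain

The source may report more compounds than this note shows. Statements on the series, on what has been measured and on what is new or still open speak of the compounds shown alone.

Compound 2 `CN(Cc1ccc(Cl)cc1)Cc1nn(-c2ccccc2F)c2c1CCS(=O)(=O)O2` and compound 1 `CCN(Cc1ccc(Br)cc1)Cc1nn(-c2ccccc2F)c2c1CCS(=O)(=O)O2` share one core. In a functional assay, with a stated time of 2 h, tested at 100 uM (on this read-out higher numbers stand for more inhibition at the one concentration tested (going by the name of the read-out) and lower numbers for less inhibition), compound 2 gives 6.1%, and in this assay compound 1 gives 12.9%; the two numbers lie within the scatter of each other, so neither stands apart. Compound 3 `CCN(Cc1ccc(Cl)cc1)Cc1nn(-c2ccccc2F)c2c1CCS(=O)(=O)O2` has not yet been measured. It differs from compound 2 by methyl in place of hydrogen on a saturated chain carbon bound to an amine nitrogen. For the measured compounds named here, no measured pair shows this change on its own. The step is expected to be small, a number 2.9 percentage points higher from compound 2 to compound 3 (within the scatter), with no direction claimed beyond the scatter. Compound 3 is expected to give 9% in this assay, between 0% and 22%.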

Compound 3, a percentage reported as inhibition, at one concentration (the size of the read-out at that concentration, not a potency): 4.2%
For compound 3 the middle estimate is 4.8 percentage points above the measured one, and the stated range covers the measured number.
By their numbers in this assay, from the lowest: compounds 3, 2 and 1 (each within the scatter of the next).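

In this assay, methyl in place of hydrogen on a saturated chain carbon bound to an amine nitrogen now has a measured step of its own (a number 1.9 percentage points lower from compound 2 to compound 3 (within the scatter)), and chloro in place of bromo on an aromatic carbon has one as well (a number 8.7 percentage points lower from compound 1 to compound 3 (within the scatter)). Both steps lie within the scatter, so neither change stands apart on this read-out. No measurement here speaks to what lies behind these numbers.

The compounds shown leave open whether a longer chain, such as propyl, or a carboxylic acid at this place on the chain would give a number beyond the scatter.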